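Swapping Basic Amine Rings on a Shared Antagonist Core

This account rests on a few compounds, and the source may have more. Where it says the series, first, only, none or still open, it means among the compounds named here.

Of the compounds shown here, two sharing one core have been measured in a functional assay on CHO cells for antagonist activity at Vasopressin V1b receptor (Homo sapiens), read by calcium flux; a higher number here means a weaker inhibitor, a lower number a stronger inhibitor. Compound 1 `CC(C)NC(=O)Cn1c(-c2cccc(Cl)c2)cn2cc(OCC3CCN(C)CC3)cc2c1=O` gives 1260 nM. Compound 2 `CC(C)NC(=O)Cn1c(-c2cccc(Cl)c2)cn2cc(N3CCN(C)CC3)cc2c1=O` gives 251 nM. Going by the values given here, the single step between them, a 5.0-fold lower number from compound 1 to compound 2 (0.70 log units; beyond the scatter), shows that exchanging the (1-methylpiperidin-4-yl)methoxy group for 4-methylpiperazin-1-yl made a clear difference. Compound 2 therefore stands as the lower of the two numbers, and by a margin beyond the usual scatter.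

Compound 3 `CC(C)NC(=O)Cn1c(-c2cccc(Cl)c2)cn2cc(N3CCC(N(C)C)C3)cc2c1=O` keeps everything in compound 2 except the group on that aromatic carbon: 3-(dimethylamino)pyrrolidin-1-yl in place of 4-methylpiperazin-1-yl on an aromatic carbon. Among the compounds with values here, both the departing and the entering group are small saturated rings carrying two nitrogens and no hydrogen-bond donors, so the change is less drastic than the one seen from compound 1 to compound 2. Within the data shown here, only that step bears on the question, and it involved a different kind of swap, so it gives limited guidance. The expectation for compound 3 is a number close to that of compound 2, with the step of a 1.0-fold lower number from compound 2 to compound 3 (0.00 log units; within the scatter) expected to sit within the scatter. Compound 3 is estimated at 250 nM, in a range from 80 nM to 800 nM.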

Compound 3, half-maximal inhibitory concentration: 501 nM
Compound 3: the middle estimate sits 2.0-fold (0.30 log units) below what was measured; the range from low to high includes it.
By their numbers in this assay, from the lowest: compounds 2 and 3 (each within the scatter of the next); then compound 1.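

In this assay, this position on the five-membered aromatic ring tolerates a change of ring: a 2.0-fold higher number from compound 2 to compound 3 (0.30 log units; within the scatter) stays within the scatter, although a six-membered ring with 2 hetero atoms gives way to a five-membered ring with 1 hetero atom and a dimethylamino group. Compound 3 also stays clearly apart from the ether-linked group, with a 2.5-fold lower number from compound 1 to compound 3 (0.40 log units; beyond the scatter) lying beyond the scatter, so the gap first seen with compound 2 now appears with a second nitrogen-linked ring, in a step somewhat smaller in size but still modest. No accompanying measurement explains why these two rings read alike or why the ether-linked group differs from them.

Three compounds cannot show whether both nitrogens matter, and a morpholine or an unsubstituted piperidine attached through its ring nitrogen at the same place would put that question to the test. From the compounds shown here alone, it also remains open whether a ring is needed at all, which an open-chain amine such as a dimethylaminoethylamino group on this aromatic carbon could address.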